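This account rests on a few compounds, and the source may have more. Where it says the series, first, only, none or still open, it means among the compounds named here.

Measured so far, with half-lives in a physicochemical assay for pharmacokinetics, read by LC-MS, in phosphate buffer, at pH 7.4, in the presence of a further agent that is not named here; a higher number here means that the compound lasts longer, a lower number that the compound disappears faster:
compound 1 `C=CC(=O)N1CC(NC(=O)Cn2cc(C(=O)N3CCc4ccccc4C3)c3cc(Br)ccc32)C1` gives 1.67 h;
compound 2 `C=CC(=O)N1CC(NC(=O)Cn2cc(C(=O)N3CCc4c(F)cccc4C3)c3cc(Br)ccc32)C1` gives 1.67 h;
compound 3 `C=CC(=O)N1CC(NC(=O)Cn2cc(C(=O)N3CCc4cc(Cl)ccc4C3)c3cc(Br)ccc32)C1` gives 1.67 h.

Compound 3 stands level with compounds 1 and 2: all three read the same in this assay. The steps among them confirm this: no change at the digits printed from compound 1 to compound 2 (within the scatter), no change at the digits printed from compound 1 to compound 3 (within the scatter), and no change at the digits printed from compound 2 to compound 3 (within the scatter). Neither a fluoro nor a chloro in place of hydrogen on an aromatic carbon, nor the exchange of one substituted group for the other on the carbonyl carbon, moved the half-life beyond the scatter.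

Compound 4 `C=CC(=O)N1CC(NC(=O)Cn2cc(C(=O)N3CCc4c(Cl)cccc4C3)c3cc(Br)ccc32)C1` differs from compound 3 in one place: a group of 11 heavy atoms (9 carbon, 1 nitrogen, 1 chlorine; one six-membered non-aromatic ring with 1 hetero atom, one six-membered aromatic ring of carbon only) in place of a group of 11 heavy atoms (9 carbon, 1 nitrogen, 1 chlorine; one six-membered non-aromatic ring with 1 hetero atom, one six-membered aromatic ring of carbon only), on a carbonyl carbon. The two have the same atoms, joined differently. Going by the values given here, no measured step is this exact move, but all three measured steps alter the same group on the carbonyl carbon whose other neighbour is an aromatic carbon, and each of them left the half-life in this assay unchanged within the scatter. On that basis the step of no change at the digits printed from compound 3 to compound 4 (within the scatter) is expected to be none beyond the scatter. The estimate for compound 4 in this assay is therefore 1.67 h, with a range from 0.9 h to 3.2 h.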

Compound 4, half-life: 1.67 h
The estimate for compound 4 equals the measured number at the digits printed, and the stated range covers the measured number.
By their numbers in this assay, from the lowest: compounds 1, 2, 3 and 4 (each within the scatter of the next).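

In this assay, compound 4 has the same atoms as compound 3 joined differently, and the half-life shows no change at the digits printed from compound 3 to compound 4 (within the scatter). This adds a rearrangement of the chlorine-bearing group on the carbonyl carbon to the single replacements seen earlier, and the new compound also adds a direct swap of one halogen for another, with no change at the digits printed from compound 2 to compound 4 (within the scatter), alongside a further replacement of hydrogen, with no change at the digits printed from compound 1 to compound 4 (within the scatter). No accompanying measurement offers an explanation for these readings.

Every change shown lies in the group on the carbonyl carbon and involves only hydrogen, fluoro or chloro, so it remains open whether a methoxy, an amine or a carboxylic acid on that group would give the same reading in this assay. Also open, going by these compounds, is how the half-life would respond to a change in the shared core, such as a nitrile in place of its bromine, and the matching readings do not show how far this half-life can move.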